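The source may hold more compounds than are shown below. What is called first, only, known or untested is meant among the compounds shown, and "the series" means these compounds.

Three compounds that share one core and differ only in a group on an aromatic carbon have been measured in an ADME assay on microsomes from liver (Mus musculus) for metabolic stability, read by LC-MS, with a stated time of 10 min; a lower number here means that less of the compound is left, a higher number that more of the compound is left. Compound 3 `CN(C[C@H]1Cc2c(cccc2N2CCN3CCC[C@@H]3C2)CN1)[C@H]1CCCc2cccnc21` gives 36.7%. Compound 2 `CN(C[C@H]1Cc2c(cccc2N2CCNC(C)(C)C2)CN1)[C@H]1CCCc2cccnc21` gives 44%, and the data show a number 7.3 percentage points lower from compound 2 to compound 3 (within the scatter), so these two cannot be told apart. Compound 1 `CN(C[C@H]1Cc2c(cccc2N2CCN(C3CC3)CC2)CN1)[C@H]1CCCc2cccnc21` gives 7% and stands apart from both, with a number 29.7 percentage points higher from compound 1 to compound 3 (beyond the scatter) and a number 37 percentage points higher from compound 1 to compound 2 (beyond the scatter).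

Compound 4 `C[C@@H]1CN(c2cccc3c2C[C@H](CN(C)[C@H]2CCCc4cccnc42)NC3)C[C@H](C)N1C` has not yet been measured. It differs from compound 3 at that same place: a group of 9 heavy atoms (7 carbon, 2 nitrogen; one six-membered non-aromatic ring with 2 hetero atoms) in place of a group of 9 heavy atoms (7 carbon, 2 nitrogen; one five-membered non-aromatic ring with 1 hetero atom, one six-membered non-aromatic ring with 2 hetero atoms), on an aromatic carbon. The group with one five-membered and one six-membered non-aromatic ring leaves, and 3,4,5-trimethylpiperazin-1-yl enters, with a single six-membered non-aromatic ring.

For the measured compounds named here, no measured step makes this exact swap, so the guidance is indirect. The name of the entering group echoes both 3,3-dimethylpiperazin-1-yl in compound 2 at 44% and 4-cyclopropylpiperazin-1-yl in compound 1 at 7%. The large gap between those two values warns that a change here can matter, so the range must stay wide. Still, the closer match is expected to be compound 2, and the expected change is a number 6.7 percentage points lower from compound 3 to compound 4 (within the scatter), with no step beyond the scatter expected. For compound 4 the estimated value is 30%, with an expected range from 12% to 50%.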

Compound 4, percent of the compound remaining: 39.6%
Estimate against measurement, compound 4: 9.6 percentage points below; low and high end bracket the measured number.
By their numbers in this assay, from the lowest: compound 1; then compounds 3, 4 and 2 (each within the scatter of the next).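

In this assay, the result adds a third distinct group to the stable cluster: with 3,4,5-trimethylpiperazin-1-yl in place, the data show a number 2.9 percentage points higher from compound 3 to compound 4 (within the scatter) and a number 4.4 percentage points lower from compound 2 to compound 4 (within the scatter), so the three compounds cannot be told apart. The contrast with the low end also holds for this new group, with a number 32.6 percentage points higher from compound 1 to compound 4 (beyond the scatter), which leaves the 4-cyclopropylpiperazin-1-yl group as the only one of the four set apart, and shows that a substituent on the ring nitrogen furthest from the aromatic carbon does not by itself give the low number, as the methyl group there in compound 4 shows. Nothing measured here explains why the groups divide this way.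

Compound 1 differs from the other three both in its cyclopropyl group and in having no further substituent on the carbons of its piperazine ring, so the compounds shown cannot separate these two features. As far as these compounds go, a 4-methylpiperazin-1-yl group, with a methyl on that nitrogen and bare ring carbons, or a 4-ethylpiperazin-1-yl group, would help to tell them apart, and whether a morpholin-4-yl group, with oxygen in the ring, would fit either side also stays open.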